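Solubility from compound 2 to its pyridine analogue

The source may hold more compounds than are shown below. What is called first, only, known or untested is meant among the compounds shown, and "the series" means these compounds.

Measured compounds:
- compound 1 `C[C@H](NC(=O)Cn1nnc2ccccc2c1=O)c1ccc(Cl)cc1`: 1900 nM
- compound 2 `COc1ccc([C@H](C)NC(=O)Cn2nnc3ccccc3c2=O)cc1`: 15000 nM

In a physicochemical assay for solubility, read by HPLC, in phosphate buffer, with a stated time of 16 h, at pH 6.8 (on this read-out higher numbers stand for higher solubility and lower numbers for lower solubility), compound 2 holds the higher of the two numbers at 15000 nM, while compound 1 gives 1900 nM. The next compound to be measured is compound 3 `Cc1ccc([C@H](C)NC(=O)Cn2nnc3ccccc3c2=O)nc1`, which differs from compound 2 in one place: 5-methylpyridin-2-yl in place of 4-methoxyphenyl on a saturated chain carbon bound to an amide-type nitrogen and a saturated chain carbon. Here 5-methylpyridin-2-yl stands in place of 4-methoxyphenyl on a saturated chain carbon bound to an amide-type nitrogen and a saturated chain carbon.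

For the measured compounds named here, only one measured step bears on this change: a 7.9-fold higher number from compound 1 to compound 2 (0.90 log units; beyond the scatter). It is modest but beyond the scatter, and it replaced chloro with methoxy on an aromatic carbon. Going by the values given here, no measured step replaces the aromatic ring itself, so this guide is only a loose one. A somewhat smaller step in the same direction is therefore expected, and the range must stay wide on both sides. The expected change is a 2.3-fold higher number from compound 2 to compound 3 (0.37 log units; beyond the scatter). For compound 3 the estimate is 35000 nM, with an expected range from 10000 nM to 120000 nM.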

Compound 3, solubility: 2000 nM
Compound 3: middle estimate off by 18-fold (1.24 log units), on the high side; measured number below the stated range.
By their numbers in this assay, from the lowest: compounds 1 and 3 (each within the scatter of the next); then compound 2.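

In this assay, for the compounds shown here, the 5-methylpyridin-2-yl group in place of 4-methoxyphenyl, on the saturated chain carbon bound to an amide-type nitrogen and a saturated chain carbon, gives a 7.5-fold lower number from compound 2 to compound 3 (0.88 log units; beyond the scatter) and this is the first measured replacement of the aromatic ring itself at this position, with a step beyond the scatter that runs downward, whereas the only earlier step, on an aromatic carbon, ran upward. Set against the 4-chlorophenyl group, the same 5-methylpyridin-2-yl group gives a 1.1-fold higher number from compound 1 to compound 3 (0.02 log units; within the scatter) and so that pair stands level within the scatter, leaving compound 2 apart from both. Nothing at hand accounts for the size or the direction of this change.

The compounds shown leave open whether the number for compound 3 follows from the hetero atom in the ring, from the methyl group, or from the two together. As far as these compounds go, how a 4-methylphenyl group or a 5-methoxypyridin-2-yl group would read at this position in this assay remains open as well, and either would help to separate these two parts of the change.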